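The source may report more compounds than this note shows. Statements on the series, on what has been measured and on what is new or still open speak of the compounds shown alone.

Compound 3 `Cc1ccccc1Cn1cc(COc2ccc3c(=O)ccoc3c2)nn1` carries a 2-methylphenyl group on a saturated chain carbon bound to an aromatic nitrogen. In a functional assay on SGC-7901 cells (Homo sapiens) for cytotoxicity, read by MTT assay, with a stated time of 48 h (a lower number here means a stronger inhibitor, a higher number a weaker inhibitor), compound 3 gives only a limit, > 100000 nM. Compound 1 `Cc1cccc(Cn2cc(COc3ccc4c(=O)ccoc4c3)nn2)c1` and compound 2 `O=c1ccoc2cc(OCc3cn(Cc4cccc(Br)c4)nn3)ccc12` differ from it in that same place. In this assay compound 1 gives a limit, > 100000 nM. In this assay compound 2 likewise gives a limit, > 100000 nM. Among the compounds with values here, the steps a step that the two limits leave unreadable from compound 1 to compound 3, a step that the two limits leave unreadable from compound 2 to compound 3 and a step that the two limits leave unreadable from compound 1 to compound 2 therefore cannot be read; the only evidence is the limit of > 100000 nM in this assay, at which 3 of the 3 values shown sit. Compound 4 `O=c1ccoc2cc(OCc3cn(Cc4ccc(Cl)cc4Cl)nn3)ccc12` brings the change (2,4-dichlorophenyl in place of 2-methylphenyl on a saturated chain carbon bound to an aromatic nitrogen). Within the data shown here, no measured step shows this change moving the value, so compound 4 is expected to remain at the limit, with the expected step being a number no higher from compound 3 to compound 4 (the limit leaves the size open). Compound 4 is estimated at 100000 nM, within 30000 nM to 300000 nM.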

Compound 4, half-maximal inhibitory concentration: > 100000 nM
Compound 4 gave a limit, no number (the forecaster's own chance of this, stated with the estimate: 85%); the middle value sits exactly at the limit.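

Within the data shown here, compound 4 also gives only a limit, so no step between it and compound 1, compound 2 or compound 3 can be read: the limit of > 100000 nM in this assay, at which 4 of the 4 values shown sit. The compounds shown leave open whether changing the group on the saturated chain carbon alters the value in this assay at all.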